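Adding a second methyl to the aryl ring on the core

The source may hold more compounds than are shown below. What is called first, only, known or untested is meant among the compounds shown, and "the series" means these compounds.

Compound 1 `Cc1ccccc1-c1cnnc(NCc2cc(-c3ccccc3)[nH]n2)n1` and compound 2 `Cc1ccc(-c2cnnc(NCc3cc(-c4ccccc4)[nH]n3)n2)cc1` share the same core and differ only in the methylphenyl group attached to it. In an ADME assay on CEM174 cells (Homo sapiens) for cytotoxicity (on this read-out higher numbers stand for lower toxicity in this test and lower numbers for higher toxicity in this test), compound 1 gives only a limit, > 10000 nM. In this assay compound 2 also gives only a limit, > 10000 nM. The step that the two limits leave unreadable from compound 1 to compound 2 therefore has no readable size, since both ends are limits. Compound 2 thus stands at the limit of > 10000 nM in this assay, at which 2 of the 2 values shown sit, without a number of its own. Compound 3 `Cc1cccc(C)c1-c1cnnc(NCc2cc(-c3ccccc3)[nH]n2)n1` differs from compound 2 by 2,6-dimethylphenyl in place of 4-methylphenyl on an aromatic carbon. Going by the values given here, the only measured step in this assay bears on this change, but its size cannot be read, so no step beyond the scatter can be expected in either direction. The expected step that the limit leaves unreadable from compound 2 to compound 3 is therefore no change beyond the scatter. Compound 3 is expected to give 20000 nM, within 8000 nM to 60000 nM, most likely again reported as a limit.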

Compound 3, half-maximal cytotoxic concentration: > 10000 nM
Compound 3 was reported as a limit; the forecaster's own chance of this, stated with the estimate: 85%; the middle value lies beyond the limit too.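

In this assay, going by these compounds alone, compound 1, compound 2 and compound 3 all give only a limit, so no step among them can be read. The compounds shown leave open how far each lies from that limit, and whether moving or adding methyl groups on this ring changes the read-out at all.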